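This account rests on a few compounds, and the source may have more. Where it says the series, first, only, none or still open, it means among the compounds named here.

Measured in a functional assay on A20 cells (Mus musculus) for inhibition, with stated times of 1 h, 16 h and 24 h; on this read-out lower numbers stand for stronger inhibition and higher numbers for weaker inhibition:
Compound 1 `N#CCNC(=O)[C@@H]1C[C@@H](S(=O)(=O)CC2CC2)C[C@H]1C(=O)N1CCOCC1`: 4510 nM
Compound 2 `N#CCNC(=O)[C@@H]1C[C@@H](S(=O)(=O)c2ccccc2C(F)(F)F)C[C@H]1C(=O)N1CCOCC1`: 2 nM
Compound 3 `CN1CCN(C(=O)[C@@H]2C[C@H](S(=O)(=O)c3ccccc3)C[C@H]2C(=O)NC2(C#N)CC2)CC1`: 17 nM

Compound 3, at 17 nM, holds the middle place of the three numbers, with compound 2 lower and compound 1 far higher. Compound 4 `N#CC1(NC(=O)[C@@H]2C[C@@H](S(=O)(=O)c3ccccc3)C[C@H]2C(=O)Nc2ccc(F)cc2)CC1` differs from compound 3 in one place: (4-fluorophenyl)amino in place of 4-methylpiperazin-1-yl on a carbonyl carbon. In words, (4-fluorophenyl)amino stands in place of 4-methylpiperazin-1-yl on a carbonyl carbon. Within the data shown here, the only measured step, a 2300-fold lower number from compound 1 to compound 2 (3.35 log units; beyond the scatter), is large, but it lies on a sulfonyl sulfur, so it offers no direct guide for a change on this carbonyl carbon. Among the measured compounds shown here, no measured step covers this change, so no direction can be argued and no shift beyond the scatter is expected in this assay. The expected step is a 1.2-fold higher number from compound 3 to compound 4 (0.07 log units; within the scatter). For compound 4 the estimated value is 20 nM, with an expected range from 4 nM to 100 nM.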

Compound 4, half-maximal inhibitory concentration: 391 nM
Estimate against measurement, compound 4: 20-fold (1.29 log units) below; the measured number lies above the stated range.
By their numbers in this assay, from the lowest: compound 2; then compound 3; then compound 4; then compound 1.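

In this assay, placing (4-fluorophenyl)amino where 4-methylpiperazin-1-yl stood on this carbonyl carbon gives a 23-fold higher number from compound 3 to compound 4 (1.36 log units; beyond the scatter). Among these compounds, this shows that inhibition is sensitive to the group on this carbonyl carbon, a position that no earlier step had probed, and that the change weakens inhibition. Nothing available here accounts for this loss. From the compounds shown here alone, it remains open whether the aromatic ring, the fluorine or the amide hydrogen goes with the weaker inhibition. Cyclohexylamino, unsubstituted phenylamino or piperidin-1-yl on this carbonyl carbon would help separate these features.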